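Propyl to Benzyl Carbamate on a Selenocyanate Core

The source may report more compounds than this note shows. Statements on the series, on what has been measured and on what is new or still open speak of the compounds shown alone.

Of the compounds shown here, two sharing a selenocyanate core have been tested in an ADME assay on 184B5 cells (Homo sapiens) for cytotoxicity, read by MTT assay, with a stated time of 72 h; a lower number here means a stronger inhibitor of growth, a higher number a weaker inhibitor of growth. Compound 1 `CCCOC(=O)Nc1ccc([Se]C#N)cc1` carries a propyl carbamate and gives 9100 nM. Compound 2 `N#C[Se]c1ccc(NC(=O)Oc2ccc(F)cc2)cc1` carries an aryl carbamate instead and gives 29500 nM in this assay. Compound 1 therefore stands with the lower of the two numbers, and the gap between compound 1 and compound 2 lies beyond the usual scatter of this measurement.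

Compound 3 `N#C[Se]c1ccc(NC(=O)OCc2ccccc2)cc1` differs from compound 1 in one place: phenyl in place of ethyl on a saturated chain carbon bound to an oxygen next to a carbonyl group. Among the measured compounds shown here, no pair of measured compounds shows this exact change, so the expected size of the step rests only on the two values above. The step from compound 1 to compound 3 is expected to be small, a 1.3-fold higher number from compound 1 to compound 3 (0.12 log units; within the scatter), and not clearly beyond the scatter. Compound 3 is estimated at 12000 nM in this assay, with a range from 5000 nM to 35000 nM.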

Compound 3, concentration for total growth inhibition: 21900 nM
Beside the measured number, compound 3's estimate is 1.8-fold (0.26 log units) below it, within the range that was stated.
By their numbers in this assay, from the lowest: compound 1; then compounds 3 and 2 (each within the scatter of the next).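

Replacing ethyl with phenyl on a saturated chain carbon bound to an oxygen next to a carbonyl group gives a 2.4-fold higher number from compound 1 to compound 3 (0.38 log units; beyond the scatter) in this assay. This is the first change in one place among the compounds shown, so it gives the first direct evidence that this position affects the result: here, the phenyl group goes with weaker growth inhibition, by a modest step. Nothing available explains why this step occurs.

A single step cannot show whether the aromatic ring matters or whether any group with more carbon atoms than ethyl would act in the same way. A butyl chain or a cyclohexyl ring in this place could separate those two readings, and a methyl group or a hydroxyl-bearing chain would show how far the trend extends.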